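Methoxy in Place of Amino: Estimating Compound 4

The source may hold more compounds than are shown below. What is called first, only, known or untested is meant among the compounds shown, and "the series" means these compounds.

Measured compounds:
compound 1 `COc1ccc(-c2cc(/C=C/C(=O)c3ccc(N)cc3)[nH]n2)cc1`: 97%
compound 2 `COc1cc(-c2cc(/C=C/C(=O)c3ccc(N)cc3)[nH]n2)cc(OC)c1OC`: 93%
compound 3 `COc1ccc(C(=O)/C=C/c2cc(-c3cc(OC)c(OC)c(OC)c3)n[nH]2)cc1OC`: 107%

In a functional assay on COLO 205 cells (Homo sapiens) for cytotoxicity, read by sulforhodamine B assay, with a stated time of 48 h, tested at 0.01 uM (a lower number here means a stronger effect, a higher number a weaker effect of the compound at the concentration tested), compound 2 gives 93%, the lowest of the three numbers. Compound 1 stands nearest to it, and the two lie within the scatter of each other. Within the data shown here, compound 3 stands furthest, and the difference a number 14 percentage points higher from compound 2 to compound 3 (beyond the scatter) is the only measured step that bears on the question here. That step exchanged 4-aminophenyl for 3,4-dimethoxyphenyl on the carbonyl carbon.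

Compound 4 `COc1ccc(C(=O)/C=C/c2cc(-c3cc(OC)c(OC)c(OC)c3)n[nH]2)cc1` differs from compound 2 by methoxy in place of amino on an aromatic carbon. Among the measured compounds shown here, the change is smaller than the one from compound 2 to compound 3, but it points the same way, replacing the amino group with a methoxy group. Because a number 14 percentage points higher from compound 2 to compound 3 (beyond the scatter) was modest yet beyond the scatter, a step of similar direction and somewhat smaller size is expected in this assay for compound 4, namely a number 9 percentage points higher from compound 2 to compound 4 (within the scatter). Compound 4 is therefore estimated at 102%, with a range from 90% to 112%.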

Compound 4, a percentage reported as activity, at one concentration (the size of the read-out at that concentration, not a potency): 103%
Compound 4: middle estimate off by 1 percentage points, on the low side, within the range that was stated.
By their numbers in this assay, from the lowest: compounds 2, 1, 4 and 3 (each within the scatter of the next, the first and the last beyond it).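

In this assay, the exchange of 4-aminophenyl for 4-methoxyphenyl gives a number 10 percentage points higher from compound 2 to compound 4 (within the scatter), so this single change at the carbon para to a large group does not clear the scatter on its own. The further methoxy of compound 3 is no clearer: hydrogen in its place gives a number 4 percentage points lower from compound 3 to compound 4 (within the scatter), and the step of a number 14 percentage points higher from compound 2 to compound 3 (beyond the scatter) thus divides into two parts, each within the scatter. Nothing available gives a reason for these numbers.

As far as these compounds go, whether a hydroxy group or a dimethylamino group in that place would give a number set apart from these remains open, as does whether the same exchange reads alike on the core of compound 1. All of these numbers also come from one concentration, so they leave the potency of the compounds open.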